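This account rests on a few compounds, and the source may have more. Where it says the series, first, only, none or still open, it means among the compounds named here.

For the measured compounds named here, in a functional assay on DU-145 cells (Homo sapiens) for antiproliferative activity, read by MTT assay, with a stated time of 48 h (a higher number here means a weaker inhibitor, a lower number a stronger inhibitor), compound 2 `C#CCOC(=O)/C(C)=C/CC/C(C)=C/CC/C(C)=C/CC[C@@H]1[C@@]2(C)CCC(=O)C(C)(C)[C@H]2CC[C@@]1(C)O` gives 46100 nM, the only true number so far. Compound 1 `C/C(=C\CC/C(C)=C/CC[C@@H]1[C@@]2(C)CCC(=O)C(C)(C)[C@H]2CC[C@@]1(C)O)CC/C=C(\C)C(=O)OCc1cn(-c2ccc(F)cc2)nn1` gives > 150000 nM, which is a limit and not a number. Compound 3 `C/C(=C\CC/C(C)=C/CC[C@@H]1[C@@]2(C)CCC(=O)C(C)(C)[C@H]2CC[C@@]1(C)O)CC/C=C(\C)C(=O)OCc1cn(-c2cccc(Br)c2)nn1` differs from compound 2 by 1-(3-bromophenyl)-1H-1,2,3-triazol-4-yl in place of ethynyl on a saturated chain carbon bound to an oxygen next to a carbonyl group: 1-(3-bromophenyl)-1H-1,2,3-triazol-4-yl in place of ethynyl. Going by the values given here, one measured step bears on this, the opposite swap of a related aryl triazole for ethynyl, an at least 3.2-fold lower number from compound 1 to compound 2 (0.51 log units; beyond the scatter). A rise of similar size is therefore expected, with the expected step being a 2.6-fold higher number from compound 2 to compound 3 (0.42 log units; beyond the scatter). Compound 3 is expected at 120000 nM, with an estimated range of 40000 nM to 300000 nM.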

Compound 3, half-maximal inhibitory concentration: > 150000 nM
Compound 3 gave a limit, no number; the forecaster's own chance of this, stated with the estimate: 50%; middle value at least 1.2-fold (0.09 log units) away from the limit.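

In this assay, putting an aryl triazole in place of ethynyl on this saturated chain carbon again gives a weaker result, with an at least 3.2-fold higher number from compound 2 to compound 3 (0.51 log units; beyond the scatter). The loss therefore appears with both a 4-fluorophenyl and a 3-bromophenyl on the triazole, not with one aryl group alone. The swap between these two aryl groups cannot be read, because both compounds stand at a limit of the assay: the limit of > 150000 nM in this assay, at which 2 of the 3 values shown sit.

From the compounds shown here alone, how far beyond that limit either triazole lies remains open. Also open, going by these compounds, is whether a triazole carrying an aminoethyl chain instead of an aryl ring would come closer to compound 2.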